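Swapping chloro for bromo on compound 1

The source may hold more compounds than are shown below. What is called first, only, known or untested is meant among the compounds shown, and "the series" means these compounds.

Among the compounds with values here, only three compounds have numbers so far in a functional assay on DU-145 cells (Homo sapiens) for inhibition, read by trypan blue exclusion, with a stated time of 96 h; on this read-out higher numbers stand for weaker inhibition of growth and lower numbers for stronger inhibition of growth. Compound 1 `O=C(/C(=C\c1ccc(Cl)cc1)S(=O)(=O)c1ccc(Br)cc1)c1ccc(Br)cc1` gives 50000 nM and compound 3 `CCOc1ccc(/C=C(/SCc2ccc(F)cc2)C(=O)c2ccc(Br)cc2)cc1OC` gives 50000 nM, so the two stand level at the top of these few numbers, the end that means weaker inhibition of growth. Compound 2 `O=C(/C(=C\c1ccc(O)cc1)SCc1ccc(Cl)cc1)c1ccc(Br)cc1` gives 10000 nM, a lower number that lies beyond the usual scatter when set against compound 1.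

Compound 4 `O=C(/C(=C\c1ccc(Br)cc1)S(=O)(=O)c1ccc(Br)cc1)c1ccc(Br)cc1` has not yet been measured. It differs from compound 1 in a single place: bromo in place of chloro on an aromatic carbon. This puts bromo in place of chloro on an aromatic carbon, turning a 4-chlorophenyl into a 4-bromophenyl, and the rest of the structure stays the same. Within the data shown here, no measured pair differs in just one place, so the data give no direct guide to the size of such a swap. The closest guide is compound 1 itself at 50000 nM, and no step beyond the scatter is expected in this assay. The estimated step of no change at the digits printed from compound 1 to compound 4 (within the scatter) therefore stays within the usual scatter. For compound 4 the estimated value is 50000 nM, with an expected range of 20000 nM to 100000 nM.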

Compound 4, concentration for 50% growth inhibition: 10000 nM
For compound 4 the middle estimate is 5.0-fold (0.70 log units) above the measured one, and the stated range ends above it.
By their numbers in this assay, from the lowest: compounds 2 and 4 (each within the scatter of the next); then compounds 1 and 3 (each within the scatter of the next).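

In this assay, this position responds to the identity of the halogen: going from 4-chlorophenyl to 4-bromophenyl gives a 5.0-fold lower number from compound 1 to compound 4 (0.70 log units; beyond the scatter), a modest step, but one that lies beyond the scatter. The swap exchanges one heavy atom for one heavy atom and leaves the counts of rings, hydrogen-bond donors, hydrogen-bond acceptors and net charge unchanged, so those counts alone do not separate compound 1 from compound 4. No supporting measurement is available to explain the step, and its cause remains unknown.

This is a single step at a single position, so it sets no trend: an iodo group, an amine or a carboxylic acid at the same place could each fall anywhere relative to compound 4. As far as these compounds go, it also remains open whether the same chloro-to-bromo swap would produce a similar step in compounds built like compound 2 or compound 3, which differ from compound 1 in more than one place and so cannot be compared directly with it.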